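The source may hold more compounds than are shown below. What is called first, only, known or untested is meant among the compounds shown, and "the series" means these compounds.

Measured so far in a functional assay on MCF7 cells (Homo sapiens) for cytotoxicity, read by MTT assay, with a stated time of 72 h; on this read-out higher numbers stand for weaker inhibition and lower numbers for stronger inhibition:
compound 1 `COc1cc2ncnc(Nc3ccc(F)c(Cl)c3)c2cc1NC(=O)N/N=C/c1cccc(Br)c1`: 27100 nM
compound 2 `COc1cc2ncnc(Nc3ccc(F)c(Cl)c3)c2cc1NC(=O)N/N=C/c1ccc(C#N)cc1`: "not determined" (no result reported)
compound 3 `COc1cc2ncnc(Nc3ccc(F)c(Cl)c3)c2cc1NC(=O)N/N=C/c1ccc(F)cc1Cl`: "not active" (no number reported)

Compound 3 has no single number: its entry reads "not active" (no number reported). Compound 2, at "not determined" (no result reported), is the other entry without one. Going by the values given here, only compound 1 gives a number, 27100 nM, so the series offers no step between measured compounds, and compound 3 cannot be placed on a numerical scale.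

Next is compound 4 `COc1cc2ncnc(Nc3ccc(F)c(Cl)c3)c2cc1NC(=O)N/N=C/c1cc(OC)c(OC)c(OC)c1`, which keeps the shared core and has 3,4,5-trimethoxyphenyl in place of 2-chloro-4-fluorophenyl on a carbon with a double bond to nitrogen. The data hold no measured effect of this exchange, and the expectation rests on very little.

In this assay the expectation is a level close to that of compound 1, which gives 27100 nM, with no clear move in either direction. Compound 4 may also, like compound 3, return no number at all. For compound 4 the estimated value is 25000 nM, with an expected range from 8000 nM to 70000 nM.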

Compound 4, half-maximal inhibitory concentration: 30700 nM
Beside the measured number, compound 4's estimate is 1.2-fold (0.09 log units) below it; the measured number falls inside the stated range.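

In this assay, putting 3,4,5-trimethoxyphenyl in place of 3-bromophenyl on a carbon with a double bond to nitrogen gives a 1.1-fold higher number from compound 1 to compound 4 (0.05 log units; within the scatter) and so leaves the two groups indistinguishable on this read-out, even though the entering group carries 3 hydrogen-bond acceptors. Compound 4 reads 30700 nM and thus gives this position a second number, which shows that a measurable level here is not confined to the 3-bromophenyl of compound 1, while the exchange from compound 3 cannot be read as a step since compound 3 has no number. No evidence is at hand to account for the level of either compound.

The compounds shown leave open whether any group at this position moves the number beyond the scatter, since the only readable pair sits within it. An amine or a carboxylic acid on the aromatic ring, or a longer alkyl chain in place of that ring, would test this with groups of a different kind from the halogens and methoxy groups seen so far.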